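This account rests on a few compounds, and the source may have more. Where it says the series, first, only, none or still open, it means among the compounds named here.

The measured compounds so far:

Compound 1, `CCN(CC)Cc1ccc2nc(NC(=O)N/N=C/c3cn(Cc4ccc(C(C)(C)C)cc4)c4ccccc34)sc2c1`, gives 1710 nM in a functional assay on A549 cells (Homo sapiens) for cytotoxicity, read by MTT assay, with a stated time of 72 h; a lower number here means a stronger inhibitor, a higher number a weaker inhibitor.
Compound 2, `CN(C)Cc1ccc2nc(NC(=O)N/N=C/c3cn(Cc4ccc(C(C)(C)C)cc4)c4ccccc34)sc2c1`, gives 1850 nM in this assay.

Compound 2 stands at the highest of the two numbers, but its nearest neighbour is compound 1, and the step of a 1.1-fold higher number from compound 1 to compound 2 (0.03 log units; within the scatter) lies within the scatter, so the two compounds cannot be set in order on these values. That step concerns only the amine on the saturated chain carbon and leaves the rest of the shared core untouched.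

Compound 3, `CN(C)Cc1ccc2nc(NC(=O)N/N=C/c3c[nH]c4ccccc34)sc2c1`, differs from compound 2 in one place: hydrogen in place of 4-(tert-butyl)benzyl on an aromatic nitrogen. Among the compounds with values here, no measured step touches this position, so nothing among the measured compounds tells how large a change in this assay this removal may bring, or in which direction. The change removes a large group, and without any comparable step the estimate must remain wide. Compound 3 is expected to give about 5000 nM, plausibly between 1500 nM and 20000 nM. This estimate means a step of a 2.7-fold higher number from compound 2 to compound 3 (0.43 log units; beyond the scatter), carrying more uncertainty than the measured scatter alone.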

Compound 3, half-maximal inhibitory concentration: 3300 nM
For compound 3 the middle estimate is 1.5-fold (0.18 log units) above the measured one; the range from low to high includes it.
By their numbers in this assay, from the lowest: compounds 1, 2 and 3 (each within the scatter of the next).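

Within the data shown here, the first measurement at this position puts a size on the change: replacing 4-(tert-butyl)benzyl on the aromatic nitrogen with hydrogen gives a 1.8-fold higher number from compound 2 to compound 3 (0.25 log units; within the scatter) in this assay, so the two compounds cannot be set in order on these values. The earlier compounds shown here showed only that the amine on the saturated chain carbon could be exchanged within the scatter, whereas this result extends the finding to a far larger part of the molecule, since a group of 11 heavy atoms with its six-membered aromatic ring leaves the aromatic nitrogen and the step still lies within the scatter. Nothing available explains why the step stays this small.

The compounds shown leave open whether a methyl group, an unsubstituted benzyl group or a longer chain ending in an amine on the same aromatic nitrogen would also stay within the scatter of compound 2. They also leave open whether the same replacement would give a similar step in compound 1, which carries diethylamino on the saturated chain carbon.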